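The compounds below may be only part of what the source reports. "The series", "measured", "known", "first", "only" and "open" are said of these compounds alone.

Series notes on an assay on isolated protein for displacement of a labelled ligand from 5-hydroxytryptamine receptor 5A (Homo sapiens), read by radioligand binding, with a stated time of 2 h; on this read-out higher numbers stand for weaker inhibition and lower numbers for stronger inhibition. Compound 2 `CN(C)S(=O)(=O)CCNCc1ccc(F)c2cccnc12` is one of three entries considered here. Compound 1 `CCS(=O)(=O)CCCNCc1ccc(Cl)c2cccnc12` gives in this assay only > 10000 nM, which is a limit of the assay and not a number (the limit of > 10000 nM in this assay, at which 1 of the 3 values shown sits). Of the two numbers shown, compound 2 gives the higher one, 271 nM in this assay. Compound 3 `CN(C)S(=O)(=O)C1(CNCc2ccc(Cl)c3cccnc23)CC1` gives 107 nM in this assay, and the gap from compound 2 lies beyond the scatter. Compound 4 `CN(C)S(=O)(=O)CCNCc1cccc2cccnc12` is not yet measured; it differs from compound 2 by hydrogen in place of fluoro on an aromatic carbon. Among the compounds with values here, no measured pair in the set covers this change, so the size of the step rests on expectation alone. As far as these compounds go, every measured compound carries a halogen at that place and none lacks one, so the unsubstituted ring is untested ground; a modest weakening of inhibition is expected, by the step of a 2.0-fold higher number from compound 2 to compound 4 (0.31 log units; beyond the scatter). Compound 4 is therefore estimated at 550 nM in this assay, with a range from 150 nM to 2500 nM.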

Compound 4, inhibition constant: 229 nM
Estimate against measurement, compound 4: 2.4-fold (0.38 log units) above; the range from low to high includes it.
By their numbers in this assay, from the lowest: compound 3; then compounds 4 and 2 (each within the scatter of the next). At a limit, above all of these: compound 1.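

In this assay, hydrogen in place of fluoro on the aromatic carbon para to a large group gives the first step read at this position: a 1.2-fold lower number from compound 2 to compound 4 (0.07 log units; within the scatter). On the side chain shared by compound 2 and compound 4, the fluoro group is therefore not needed to keep the number in this range, and the unsubstituted ring is no longer untested ground. No measured property among the data shown bears on this result.

As far as these compounds go, whether a larger group at this place, such as methoxy or trifluoromethyl, would move the number remains open. Chloro also cannot be placed against fluoro or hydrogen, since compound 1 and compound 3 carry it but differ from compound 2 and compound 4 in their side chains as well.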